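Methyl at a second place on a pepsin inhibitor series

This account rests on a few compounds, and the source may have more. Where it says the series, first, only, none or still open, it means among the compounds named here.

Of the compounds shown here, three have been measured in an assay on isolated protein for inhibition of Pepsin A (Sus scrofa); on this read-out higher numbers stand for weaker inhibition and lower numbers for stronger inhibition. Compound 1 `CC(C)CCNC(=O)C(C)NC(=O)CCC(=O)[C@H](CC(C)C)NC(=O)C(NC(=O)CC(C)C)C(C)C` gives 2140 nM, compound 2 `CC(C)CC(=O)NC(C(=O)N[C@@H](CC(C)C)[C@@H](O)CC(C)C(=O)NCC(=O)NC(=O)C(C)C)C(C)C` gives 53 nM, and compound 3 `CC(C)CC(=O)NC(C(=O)N[C@@H](CC(C)C)[C@@H](O)CC(C)C(=O)NC(C)C(=O)NC(=O)C(C)C)C(C)C` gives 3 nM. The difference between the cores of compound 1 and compound 2 is not broken down here. Compound 3 differs from compound 2 by methyl in place of hydrogen on a saturated chain carbon bound to an amide-type nitrogen and a carbonyl carbon, and that change produced an 18-fold lower number from compound 2 to compound 3 (1.25 log units; beyond the scatter). Compound 4 `CC(C)CCNC(=O)C(C)NC(=O)C(C)CC(=O)[C@H](CC(C)C)NC(=O)C(NC(=O)CC(C)C)C(C)C` is not yet measured; it differs from compound 1 by methyl in place of hydrogen on a saturated chain carbon bound to a carbonyl carbon and a saturated chain carbon, the same kind of change, though the place is not the same: there the carbon is bound to an amide-type nitrogen and a carbonyl carbon, here to a carbonyl carbon and a saturated chain carbon. Because compound 2 to compound 3 gave an 18-fold lower number from compound 2 to compound 3 (1.25 log units; beyond the scatter) at a different place, a smaller step is expected here, and the step from compound 1 to compound 4 is estimated as a 3.1-fold lower number from compound 1 to compound 4 (0.49 log units; beyond the scatter). Compound 4 is expected to give about 700 nM in this assay.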

Compound 4, inhibition constant: 27 nM
Estimate against measurement, compound 4: 26-fold (1.41 log units) above, outside the stated range (below it).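

In this assay, methyl in place of hydrogen lowered the number on both cores, and on the core of compound 1 the result was a 79-fold lower number from compound 1 to compound 4 (1.90 log units; beyond the scatter). The two steps run in the same direction but differ in size: the same change on two cores in this assay, an 18-fold lower number (1.25 log units; beyond the scatter) from compound 2 to compound 3 and a 79-fold lower number (1.90 log units; beyond the scatter) from compound 1 to compound 4, 4.5-fold (0.65 log units) apart, beyond the scatter of two such steps. This shows that the direction held in these two pairs, but not that the size of the step carries from one core to another, and the methyl also sits at a different place in each pair, so the core and the place cannot be told apart here.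

The compounds shown leave open which of the two sets the size of the step. They also leave open whether an ethyl group or a longer chain on the same carbon would lower the number further.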